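The source may hold more compounds than are shown below. What is called first, only, known or untested is meant among the compounds shown, and "the series" means these compounds.

Measured in a physicochemical assay for solubility, read by chemiluminescence, measured as kinetic solubility; on this read-out higher numbers stand for higher solubility and lower numbers for lower solubility:
- compound 1 `COc1nc(NS(=O)(=O)c2cccc(Cl)c2Cl)c2c(OC)nn(C)c2n1`: 148000 nM
- compound 2 `COc1nn(C)c2nc(N)nc(NS(=O)(=O)c3cccc(Cl)c3Cl)c12`: >= 649000 nM
- compound 3 `CNc1nc(NS(=O)(=O)c2cccc(Cl)c2Cl)c2c(OC)nn(C)c2n1`: 376000 nM

Compound 2 gives >= 649000 nM, which is a limit of the assay and not a number. Of the two true numbers, the higher belongs to compound 3, and the step up to it is a 2.5-fold higher number from compound 1 to compound 3 (0.40 log units; beyond the scatter).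

The next compound to consider is compound 4 `CCNc1nc(NS(=O)(=O)c2cccc(Cl)c2Cl)c2c(OC)nn(C)c2n1`. Its difference is methyl in place of hydrogen on a saturated chain carbon bound to a nitrogen on an aromatic ring, which turns methylamino into ethylamino.

Two measured steps swap methoxy for a nitrogen group, an at least 4.3-fold higher number from compound 1 to compound 2 (0.64 log units; beyond the scatter) and the step to compound 3 already given. They show what replacing methoxy did, but they do not show what lengthening the chain does. Among the measured compounds shown here, the closest guide is the one step that also adds a methyl, although on the nitrogen rather than on a chain carbon, and it is an at least 1.7-fold lower number from compound 2 to compound 3 (0.23 log units; that floor lies within the scatter). This single step points slightly downward at most, so no step beyond the scatter is expected in this assay.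

The estimated change is a 1.4-fold lower number from compound 3 to compound 4 (0.14 log units; within the scatter), which is expected to stay within the scatter. For compound 4 the expected value is 270000 nM, with an estimated range from 110000 nM to 600000 nM.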

Compound 4, solubility: 219000 nM
Compound 4: middle estimate off by 1.2-fold (0.09 log units), on the high side, within the range that was stated.
By their numbers in this assay, from the lowest: compounds 1, 4 and 3 (each within the scatter of the next, the first and the last beyond it). At a limit, above all of these: compound 2.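

In this assay, among the compounds shown here, this is the first direct reading of a longer chain on this nitrogen: methyl in place of hydrogen on a saturated chain carbon bound to a nitrogen on an aromatic ring, turning methylamino into ethylamino, gives a 1.7-fold lower number from compound 3 to compound 4 (0.23 log units; within the scatter). Measured against methoxy, the two amino groups now read differently: methylamino gave a 2.5-fold higher number from compound 1 to compound 3 (0.40 log units; beyond the scatter), while ethylamino in place of methoxy gives a 1.5-fold higher number from compound 1 to compound 4 (0.17 log units; within the scatter), so only the methylamino step clears the scatter. Against the plain amino group, ethyl in place of hydrogen on the nitrogen gives an at least 2.9-fold lower number from compound 2 to compound 4 (0.47 log units; beyond the scatter), the only new step beyond the scatter, and it rests on a limit for compound 2 and not on a number: the limit of >= 649000 nM in this assay, at which 1 of the 4 values shown sits.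

From the compounds shown here alone, one chain step within the scatter sets no trend, so the effect of a longer chain such as propylamino, or a branched one such as isopropylamino, on the same nitrogen remains open. The compounds shown also say nothing about a chain ending in a hydroxyl group or a carboxylic acid.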